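A few compounds are considered here, and "the series" means these few. Any claim that something is new, unique, unknown or untested is made for them only; others in the source may bear on it.

Measured compounds:
compound 1 `COc1ccc(Oc2ccc([N+](=O)[O-])cc2-c2ccsc2S(=O)(=O)N2CCN(C(=S)Nc3ccc(Cl)cc3)CC2)cc1OC` — > 50000 nM
compound 2 `COc1ccc(Oc2ccc([N+](=O)[O-])cc2-c2ccsc2S(=O)(=O)N2CCN(C(=O)Nc3ccc([N+](=O)[O-])cc3)CC2)cc1OC` — > 20000 nM
compound 3 `COc1ccc(Oc2ccccc2-c2ccsc2S(=O)(=O)N2CCN(C(=O)Nc3ccc([N+](=O)[O-])cc3)CC2)cc1OC` — > 20000 nM

In an ADME assay on HEK-293T cells (Homo sapiens) for cytotoxicity, read by CCK-8 assay, with a stated time of 48 h (on this read-out lower numbers stand for stronger inhibition and higher numbers for weaker inhibition), none of the three compounds gave a number. Compound 1 reached only the limit > 50000 nM. Compound 2 likewise stopped at the limit > 20000 nM. Compound 3 too gave only the limit > 20000 nM. The step that the two limits leave unreadable from compound 2 to compound 1 therefore cannot be sized, and the same holds for a step that the two limits leave unreadable from compound 2 to compound 3; both rest on the limit of > 20000 nM in this assay, at which 2 of the 3 values shown sit, and (the limit of > 50000 nM in this assay, at which 1 of the 3 values shown sits). The change a group of 10 heavy atoms (7 carbon, 1 nitrogen, 1 sulfur, 1 chlorine; one six-membered aromatic ring of carbon only) in place of a group of 12 heavy atoms (7 carbon, 2 nitrogen, 3 oxygen; one six-membered aromatic ring of carbon only), on an amine nitrogen in a ring is the same one that makes compound 4 `COc1ccc(Oc2ccccc2-c2ccsc2S(=O)(=O)N2CCN(C(=S)Nc3ccc(Cl)cc3)CC2)cc1OC` from compound 3: a group of 10 heavy atoms (7 carbon, 1 nitrogen, 1 sulfur, 1 chlorine; one six-membered aromatic ring of carbon only) in place of a group of 12 heavy atoms (7 carbon, 2 nitrogen, 3 oxygen; one six-membered aromatic ring of carbon only), on an amine nitrogen in a ring. The two cores differ by hydrogen in place of nitro on an aromatic carbon. Among the compounds with values here, the earlier instance of this change was left without a readable size, so its repetition on the core of compound 3 gives no measured step to lean on, only three limits. Compound 4 is expected to show the step that the limit leaves unreadable from compound 3 to compound 4 and to end again at a limit. Compound 4 is estimated at 50000 nM, with an expected range from 20000 nM to 200000 nM.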

Compound 4, half-maximal inhibitory concentration: > 20000 nM
Compound 4 was reported as a limit; the forecaster's own chance of this, stated with the estimate: 90%; the middle value does not contradict the limit.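

In this assay compound 4 gives > 20000 nM, a limit and not a number, so neither of its steps, to compound 3 or to compound 1, can be read. The compounds shown leave open whether replacing the (4-nitrophenyl)carbamoyl group, or hydrogen in place of nitro, changes the read-out at all.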